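From furan-2-yl to thiophen-2-yl at the limit

The compounds below may be only part of what the source reports. "The series", "measured", "known", "first", "only" and "open" are said of these compounds alone.

Measured in a functional assay on HL-60 cells (Homo sapiens) for antiproliferative activity, read by XTT assay, with a stated time of 72 h (a higher number here means a weaker inhibitor, a lower number a stronger inhibitor), all three values being limits:
- compound 1 `CNc1ncnc2c1c(-c1cccs1)cn2[C@@H]1O[C@H](CO)[C@@H](O)[C@H]1O`: > 20000 nM
- compound 2 `Nc1nc(N)c2c(-c3ccco3)cn([C@@H]3O[C@H](CO)[C@@H](O)[C@H]3O)c2n1`: > 20000 nM
- compound 3 `COc1nc(N)nc2c1c(-c1ccco1)cn2[C@@H]1O[C@H](CO)[C@@H](O)[C@H]1O`: > 20000 nM

The record for this small set is the limit of > 20000 nM in this assay, at which 3 of the 3 values shown sit. Compound 3 has no number, only the limit > 20000 nM.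

Compound 4 `COc1nc(N)nc2c1c(-c1cccs1)cn2[C@@H]1O[C@H](CO)[C@@H](O)[C@H]1O` differs from compound 3 in one place: thiophen-2-yl in place of furan-2-yl on an aromatic carbon. In words, it carries thiophen-2-yl in place of furan-2-yl on an aromatic carbon.

Among the measured compounds shown here, the one measured step nearby is a step that the two limits leave unreadable from compound 2 to compound 3. It concerns methoxy in place of amino on an aromatic carbon, not the exchange at hand, and it gives no size to build on. For the measured compounds named here, no measured step covers the exchange of furan-2-yl for thiophen-2-yl. Compound 1 already carries thiophen-2-yl, on a core that differs from that of compound 4. The value of compound 1 is the limit > 20000 nM.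

With nothing but limits to go on, no step beyond the scatter is expected in this assay, and no direction can be named. The expected step is a number no higher from compound 3 to compound 4 (the limit leaves the size open). The most likely outcome is that the assay again reports only a limit. For compound 4 the estimate is 20000 nM, with an expected range from 7000 nM to 40000 nM.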

Compound 4, half-maximal inhibitory concentration: > 20000 nM
Compound 4: only a limit was reported; the forecaster's own chance of this, stated with the estimate: 80%; the middle value lies on the limit itself.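

In this assay compound 4 gives > 20000 nM, which is a limit and not a number. Compound 3 also has only a limit, so no step can be read between compound 3 and compound 4. The compounds shown leave open how thiophen-2-yl and furan-2-yl compare on this shared core in this assay.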